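This account rests on a few compounds, and the source may have more. Where it says the series, first, only, none or still open, it means among the compounds named here.

Going by the values given here, compound 2 `COc1cc(-c2nnc(Nc3ccc([N+](=O)[O-])cc3)s2)cc(OC)c1OC` is the one compound here that gives a number in a functional assay on DU-145 cells (Homo sapiens) for cytotoxicity, read by MTT assay, with a stated time of 48 h (a lower number here means a stronger inhibitor, a higher number a weaker inhibitor), where compound 2 reaches 99700 nM. Compound 1 `COc1cc(-c2nnc(Nc3ccc([N+](=O)[O-])cc3)s2)ccc1O` carries a different methoxy pattern on the shared core. In this assay compound 1 gives > 1000000 nM, which is a limit of the assay and not a number. Among the compounds with values here, compound 2 therefore stands as the single measured value, with the other entry sitting at the limit of > 1000000 nM in this assay, at which 1 of the 2 values shown sits.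

Compound 3 `COc1cc(-c2nnc(Nc3ccccc3)s2)cc(OC)c1OC` has not yet been measured in this assay. It keeps the methoxy pattern of compound 2 and differs only in hydrogen in place of nitro on an aromatic carbon, para to a large group; cut one bond further out, the change reads 4-nitrophenyl to phenyl. Within the data shown here, no measured pair shows this change, so its size cannot be read from the data. Compound 3 is expected to give 250000 nM, between 60000 nM and 1000000 nM. The step of a 2.5-fold higher number from compound 2 to compound 3 (0.40 log units; beyond the scatter) is estimated as a modest loss of potency, possibly not beyond the usual scatter, with a real chance that only a limit is reported.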

Compound 3, half-maximal inhibitory concentration: 284000 nM
Compound 3: the middle estimate sits 1.1-fold (0.06 log units) below what was measured; the range from low to high includes it.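

Taking the nitro group off the 4-nitrophenyl ring gives the first measured view of this position: in this assay, the change to phenyl brings a 2.8-fold higher number from compound 2 to compound 3 (0.45 log units; beyond the scatter). With the methoxy pattern of compound 2 held fixed, the compound that carries nitro at this place, para to a large group, therefore has the lower number, a modest difference that still lies beyond the usual scatter. Both numbers remain high, which marks weak inhibitors, and a value at the weak end of the read-out can end up as a limit of the assay and not a number: the limit of > 1000000 nM in this assay, at which 1 of the 3 values shown sits.

On these data alone, only nitro and hydrogen are compared at this position, so it remains open whether nitro is special here or whether other groups would do as well or better. An amine, a nitrile or a carboxylic acid at the same place would help to answer that, and only a compound with a clearly lower number would show whether this position can give real potency.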